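Replacing the Dipropylamino Group with a Bulkier Amine

This account rests on a few compounds, and the source may have more. Where it says the series, first, only, none or still open, it means among the compounds named here.

Compound 3 `CCCN(CCC)c1cccc2nc(Oc3c(OC)cc(COC)cc3OC)c(C)cc12` bears a dipropylamino group on its core. In an assay on HEK293 cells for displacement of a labelled ligand from corticotropin-releasing factor receptor 1 (Homo sapiens), read by scintillation proximity assay, with a stated time of 2 h (a higher number here means a weaker inhibitor, a lower number a stronger inhibitor), compound 3 gives 138 nM. Compound 1 `CCCN(CCC)c1cccc2nc(Nc3c(C)cc(C)cc3C)c(=O)[nH]c12` gives 100 nM in this assay, and the two values sit within the scatter of each other. Compound 2 `CCCN(CCC)c1cccc2nc(N(C)c3c(C)cc(C)cc3C)c(=O)n(C)c12` reaches only a limit in this assay, namely > 1000 nM, so it supplies no number. Among the numbers shown, compound 3 therefore has the highest, though its gap to compound 1 is within the scatter.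

Compound 4 `COCc1cc(OC)c(Oc2nc3cccc(N(CC4CC4)C4CCOCC4)c3cc2C)c(OC)c1` differs from compound 3 in a single place: (cyclopropylmethyl)(oxan-4-yl)amino in place of dipropylamino on an aromatic carbon. Going by the values given here, no measured pair shows a change of this kind, so the data give no step to lean on. A small shift in either direction, or none beyond the scatter, is what is expected. Compound 4 is estimated to give 150 nM in this assay, with a range from 50 nM to 500 nM. This estimate means a step of a 1.1-fold higher number from compound 3 to compound 4 (0.04 log units; within the scatter) that is expected to stay within the scatter.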

Compound 4, half-maximal inhibitory concentration: 157 nM
Estimate against measurement, compound 4: 1.0-fold (0.02 log units) below, within the range that was stated.
By their numbers in this assay, from the lowest: compounds 1, 3 and 4 (each within the scatter of the next). At a limit, above all of these: compound 2.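

Going by these compounds alone, the step at this position, a 1.1-fold higher number from compound 3 to compound 4 (0.06 log units; within the scatter), is the first measured change of the amine on the aromatic carbon, since the earlier compounds all carry dipropylamino there. It shows that in this assay this place accepts a group of 11 heavy atoms with two non-aromatic rings in place of an open group of 7 heavy atoms, with no shift beyond the scatter. Nothing in the data shown explains this result.

Going by these compounds, it remains open how a morpholine or a simple dimethylamino group would read at this aromatic carbon, and whether the cyclopropylmethyl or the oxan-4-yl part paired with a propyl chain would stay within the scatter of compound 3. Also open, on these data alone, is whether the same exchange would hold on the core of compound 1.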